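A Methyl on the Chain of Compound 2

The compounds below may be only part of what the source reports. "The series", "measured", "known", "first", "only" and "open" are said of these compounds alone.

Compound 1 `O=C(CCSc1nnc(-c2ccncc2)s1)Nc1ccccc1` gives > 50000 nM in an ADME assay on HepG2 cells (Homo sapiens) for cytotoxicity, with a stated time of 3 days (a lower number here means that less compound is tolerated, a higher number that more compound is tolerated), which is a limit of the assay.
Compound 2 `O=C(CCSc1nnc(-c2ccncc2)s1)Nc1c(Cl)cccc1Cl` gives 12600 nM in this assay.
Compound 3 `O=C(CCSc1nnc(-c2ccncc2)s1)Nc1ccc(Cl)cc1Cl` gives > 50000 nM in this assay, again a limit.

Going by the values given here, compound 2 therefore holds the only number in this assay; the other two values sit at the limit (the limit of > 50000 nM in this assay, at which 2 of the 3 values shown sit). Compound 4 `CC(CSc1nnc(-c2ccncc2)s1)C(=O)Nc1c(Cl)cccc1Cl` differs from compound 2 by methyl in place of hydrogen on a saturated chain carbon bound to a carbonyl carbon and a saturated chain carbon. The measured steps all concern the ring on the amide nitrogen: an at least 3.9-fold lower number from compound 1 to compound 2 (0.59 log units; beyond the scatter), an at least 3.9-fold higher number from compound 2 to compound 3 (0.59 log units; beyond the scatter), and a step that the two limits leave unreadable from compound 1 to compound 3. Among the compounds with values here, none of them touches the chain carbon, so no measured step bears on this change. The step that the estimate means, a 1.2-fold higher number from compound 2 to compound 4 (0.08 log units; within the scatter), is expected to stay within the scatter. Compound 4 is accordingly estimated at 15000 nM, between 5000 nM and 50000 nM.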

Compound 4, half-maximal cytotoxic concentration: > 50000 nM
Compound 4: a limit, no number; the forecaster's own chance of this, stated with the estimate: 25%; at least 3.3-fold (0.52 log units) between middle value and limit.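

In this assay, going by these compounds alone, the saturated chain carbon bound to a carbonyl carbon and a saturated chain carbon proves sensitive to change, which no earlier compound could show: methyl in place of hydrogen there gives an at least 3.9-fold higher number from compound 2 to compound 4 (0.59 log units; beyond the scatter). The value of compound 4, > 50000 nM, is a limit, so the full size of this step cannot be read. Compound 2 is now the only one of the four compounds with a number: the limit of > 50000 nM in this assay, at which 3 of the 4 values shown sit.

As far as these compounds go, whether ethyl or a longer chain on this carbon would give a limit too remains open. So does whether a hydroxyl group there would.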